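A few compounds are considered here, and "the series" means these few. Any claim that something is new, unique, unknown or untested is made for them only; others in the source may bear on it.

Compound 1 `Cc1cc(C)cc(N2CCN(C(=O)c3oc(C)nc3-c3ccccc3)CC2)c1` gives 0.356 ug/mL
Compound 2 `Cc1nc(-c2ccccc2)c(C(=O)N2CCN(c3ccccc3)CC2)o1` gives 9.63 ug/mL

In a toxicity assay on HUVEC cells (Homo sapiens) for inhibition (on this read-out higher numbers stand for weaker inhibition of growth and lower numbers for stronger inhibition of growth), compound 2 has the higher of the two numbers, which makes it the weaker growth inhibitor of this pair. Compound 3 `Cc1nc(-c2ccccc2)c(C(=O)N2CCN(c3cccc(C#N)c3)CC2)o1` is compound 2 with one change, cyano in place of hydrogen on an aromatic carbon, meta to a large group cyano in place of hydrogen on an aromatic carbon in the count of what leaves and enters. Among the measured compounds shown here, only one measured step bears on this change. That step, a 27-fold higher number from compound 1 to compound 2 (1.43 log units; beyond the scatter) when phenyl replaces 3,5-dimethylphenyl on an amine nitrogen in a ring, is large and beyond the scatter. Read in reverse, it links added groups on that phenyl with a lower number. For the measured compounds named here, this is thin evidence, since 3-cyanophenyl is not 3,5-dimethylphenyl and no measured compound carries cyano. A move in the same direction is therefore expected, but a smaller one. The estimated change is a 3.2-fold lower number from compound 2 to compound 3 (0.51 log units; beyond the scatter) in this assay for now. Compound 3 is expected at 3 ug/mL as the middle value, with an estimated range from 0.6 ug/mL to 12 ug/mL around it.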

Compound 3, concentration for 50% growth inhibition: 2.52 ug/mL
Compound 3: the middle estimate sits 1.2-fold (0.08 log units) above what was measured, and the stated range covers the measured number.
By their numbers in this assay, from the lowest: compound 1; then compound 3; then compound 2.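

In this assay, placing a cyano group on an aromatic carbon of the phenyl ring, meta to a large group, gives a 3.8-fold lower number from compound 2 to compound 3 (0.58 log units; beyond the scatter). The earlier pair showed a lower number only with 3,5-dimethylphenyl; this step shows that the number at this ring also falls with a group that is not methyl, and with a single added group. The change does not match the dimethyl pattern, however, as replacing 3,5-dimethylphenyl with 3-cyanophenyl gives a 7.1-fold higher number from compound 1 to compound 3 (0.85 log units; beyond the scatter), leaving compound 1 with the lowest number of the three and the strongest inhibition of growth, while no available evidence explains these differences.

The compounds shown leave open how much of the difference between compound 1 and compound 3 depends on the kind of group and how much on the substitution pattern, a question that a 3-methylphenyl or a 3,5-dicyanophenyl analogue could help to separate. From the compounds shown here alone, it also remains open whether other groups at this position, such as an amine, a methoxy group or a carboxylic acid, would lower the number as well.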